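The compounds below may be only part of what the source reports. "The series", "measured", "known", "first", "only" and "open" are said of these compounds alone.

Measured compounds:
compound 1, `CC1CCN(c2c(S(=O)(=O)c3ccc(Cl)cc3)cnc3ccc(F)cc23)CC1`, 80%;
compound 2, `COc1ccc2ncc(S(=O)(=O)c3cccc(C#N)c3)c(N3CCC(C)CC3)c2c1`, 90%;
compound 3, `Cc1cc(C)cc(S(=O)(=O)c2cnc3ccc(F)cc3c2N2CCC(C)CC2)c1`, 83%.

In an assay on isolated protein for displacement of a labelled ligand from metabotropic glutamate receptor 5 (Homo sapiens), with a stated time of 60 min, tested at 1 uM (on this read-out lower numbers stand for less inhibition and higher numbers for more inhibition at the one concentration tested (going by the name of the read-out)), compound 3 stands second of the three numbers shown. Its nearest neighbour is compound 1, and the step of a number 3 percentage points higher from compound 1 to compound 3 (within the scatter) is within the scatter. Compound 2 lies furthest from it, yet the two values are also within the scatter of each other, so the three measured compounds cannot be ordered on this read-out.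

Compound 4 is `CC1CCN(c2c(S(=O)(=O)c3cccc(C#N)c3)cnc3ccc(F)cc23)CC1`, not yet measured. It differs from compound 3 at the sulfonyl sulfur: 3-cyanophenyl in place of 3,5-dimethylphenyl on a sulfonyl sulfur. Going by the values given here, only one measured step concerns a change at that sulfonyl sulfur, a number 3 percentage points higher from compound 1 to compound 3 (within the scatter), and it was within the scatter. A 3-cyanophenyl group is also carried by compound 2, whose core differs from that of compound 3 as well, so the value of compound 2, 90%, can only show that such a group sits together with a high number. Compound 4 is therefore expected to show a step of a number 3 percentage points higher from compound 3 to compound 4 (within the scatter), that is, nothing beyond the scatter. The estimate for compound 4 in this assay is 86%, with a range from 72% to 95%.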

Compound 4, a percentage reported as inhibition, at one concentration (the size of the read-out at that concentration, not a potency): 93%
The estimate for compound 4 lay 7 percentage points below the measured number, within the range that was stated.
By their numbers in this assay, from the lowest: compounds 1, 3, 2 and 4 (each within the scatter of the next, the first and the last beyond it).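

Going by these compounds alone, on the sulfonyl sulfur, 3-cyanophenyl in place of 4-chlorophenyl gives the first step beyond the scatter in this assay (a number 13 percentage points higher from compound 1 to compound 4 (beyond the scatter)), a modest one, so a change at this position can register on this read-out. The other two steps stay within the scatter: 3-cyanophenyl in place of 3,5-dimethylphenyl (a number 10 percentage points higher from compound 3 to compound 4 (within the scatter)) does not separate those two groups, and with 3-cyanophenyl on the sulfonyl sulfur, fluoro in place of methoxy on an aromatic carbon (a number 3 percentage points higher from compound 2 to compound 4 (within the scatter)) shows no change. No measurement is available that accounts for the modest step.

On these data alone, what an aromatic ring carrying an amine or a carboxylic acid, or a saturated cyclohexyl group, would give on the sulfonyl sulfur remains open. With readings at one concentration only, the potency of these compounds also remains open.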